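The source may hold more compounds than are shown below. What is called first, only, known or untested is meant among the compounds shown, and "the series" means these compounds.

Notes on the series. Compound 1 `Oc1ccc(-c2cc(-c3cccs3)cc(-c3cccc(O)c3)n2)cc1` gives 1770 nM in a functional assay on HCT-15 cells (Homo sapiens) for cytotoxicity, read by CCK-8 assay; a lower number here means a stronger inhibitor, a higher number a weaker inhibitor. Compound 2 `Oc1ccc(-c2cc(-c3cccs3)cc(-c3ccc(O)cc3)n2)cc1` carries the change (4-hydroxyphenyl in place of 3-hydroxyphenyl on an aromatic carbon); in this assay compound 2 reports only the limit > 50000 nM, not a number. The step is an at least 28-fold higher number from compound 1 to compound 2 (1.45 log units; beyond the scatter), and its size is bounded by the limit of > 50000 nM in this assay, at which 2 of the 3 values shown sit.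

Compound 3 `Oc1cccc(-c2cc(-c3ccsc3)cc(-c3ccccc3O)n2)c1` has a different core; the difference between the two cores is not broken down here. In this assay compound 3 likewise reports only the limit > 50000 nM.

Compound 4 `Oc1ccc(-c2cc(-c3ccsc3)cc(-c3ccccc3O)n2)cc1` carries 4-hydroxyphenyl in place of 3-hydroxyphenyl on an aromatic carbon. The surroundings differ from the earlier case: here the place is meta to a 2-hydroxyphenyl group and meta to a thiophen-3-yl group, so this is the same kind of change, not the same change. The expected step from compound 3 to compound 4 is a step that the limit leaves unreadable from compound 3 to compound 4, resting on an at least 28-fold higher number from compound 1 to compound 2 (1.45 log units; beyond the scatter) and on compound 3 already sitting at the limit of > 50000 nM in this assay, at which 2 of the 3 values shown sit. Compound 4 is estimated at 90000 nM.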

Compound 4, half-maximal inhibitory concentration: > 50000 nM
Compound 4 ended at the assay's limit; the forecaster's own chance of this, stated with the estimate: 85%; the middle value does not contradict the limit.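

No step can be read from compound 3 to compound 4: both report only a limit, not a number. Still open, as far as these compounds go, is what 4-hydroxyphenyl in place of 3-hydroxyphenyl does on the core of compound 3.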